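This account rests on a few compounds, and the source may have more. Where it says the series, first, only, none or still open, it means among the compounds named here.

Compound 3 `COc1cc(C)c(S(=O)(=O)N(C)CCOCC(=O)N2CCN(C3CCN(C4CC4)CC3)CC2)c(C)c1` gives 6% in an ADME assay on microsomes from liver (Homo sapiens) for metabolic stability, with a stated time of 30 min, tested at 1 uM (a higher number here means that more of the compound is left, a lower number that less of the compound is left), the lowest of the three numbers measured. Compound 1 `COc1cc(C)c(S(=O)(=O)N(C)CCOCC(=O)N2CCC(C(C)(C)CN(C)C)CC2)c(C)c1` gives 36% in this assay, and compound 2 `COc1cc(C)c(S(=O)(=O)N(C)CCOCC(=O)N2CCC(N3CCN(C(C)C)CC3)CC2)c(C)c1` gives 54%. Within the data shown here, the only step measured between compounds that differ in one place is a number 18 percentage points higher from compound 1 to compound 2 (beyond the scatter), and it concerns a group on a saturated ring carbon, not the amine nitrogen in a ring that is altered between compound 3 and compound 4. Compound 4 `COc1cc(C)c(S(=O)(=O)N(C)CCOCC(=O)N2CCN([C@H]3CN4CCC3CC4)CC2)c(C)c1` differs from compound 3 in this way: a group of 8 heavy atoms (7 carbon, 1 nitrogen; 2 six-membered non-aromatic rings with 1 hetero atom each) in place of a group of 9 heavy atoms (8 carbon, 1 nitrogen; one three-membered non-aromatic ring of carbon only, one six-membered non-aromatic ring with 1 hetero atom), on an amine nitrogen in a ring. Among the measured compounds shown here, no measured step bears directly on this exchange, so no direction can be drawn from the data, and the change is expected to stay small, within or near the scatter, starting from the low number of compound 3. The estimate for compound 4 in this assay is therefore 12%, with a range from 3% to 30%, which amounts to an expected step of a number 6 percentage points higher from compound 3 to compound 4 (within the scatter).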

Compound 4, percent of the compound remaining: 26%
Compound 4: the middle estimate sits 14 percentage points below what was measured; the range from low to high includes it.
By their numbers in this assay, from the lowest: compound 3; then compounds 4 and 1 (each within the scatter of the next); then compound 2.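

Compound 4 shows that in this assay the group on the amine nitrogen in a ring affects the result: the group of 8 heavy atoms with 2 six-membered non-aromatic rings, in place of 1-cyclopropylpiperidin-4-yl, gives a number 20 percentage points higher from compound 3 to compound 4 (beyond the scatter) at this position. The earlier step, a number 18 percentage points higher from compound 1 to compound 2 (beyond the scatter), concerned a group on a saturated ring carbon, so this is the only step shown for this place, and the two groups have the same counts of hydrogen-bond donors and acceptors and no net charge. No measured evidence accounts for the step.

Going by these compounds, it remains open whether a 1-methylpiperidin-4-yl group would keep the low number of compound 3 6% or move towards that of compound 4. The mirror-image form of the entering group is also an open question, as its stereocentre is the only one in the series.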